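Adding a Methoxy Group to Compound 3

The source may hold more compounds than are shown below. What is called first, only, known or untested is meant among the compounds shown, and "the series" means these compounds.

Of the compounds shown here, three have been tested in a functional assay on NCI-H460 cells (Homo sapiens) for cytotoxicity, read by MTT assay, with a stated time of 48 h; on this read-out higher numbers stand for weaker inhibition and lower numbers for stronger inhibition; every result so far is a limit of the assay rather than a number.

Compound 1 `COc1ccc(/C=C/C(=O)/C=C/c2cc3ccccc3nc2Cl)cc1`: > 10000 nM
Compound 2 `COc1ccc(/C=C/C(=O)/C=C/c2cc3ccccc3nc2Cl)c(OC)c1`: > 10000 nM
Compound 3 `COc1ccc(/C=C/C(=O)/C=C/c2cc3ccccc3nc2Oc2ccccc2)cc1`: > 10000 nM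

Compound 3 therefore sits at the limit of > 10000 nM in this assay, at which 3 of the 3 values shown sit, with no readable number of its own. Compound 4 `COc1ccc(/C=C/C(=O)/C=C/c2cc3ccccc3nc2Oc2ccccc2)c(OC)c1` differs from it by methoxy in place of hydrogen on an aromatic carbon. The same kind of change has been made once before, as a step that the two limits leave unreadable from compound 1 to compound 2, and the other measured step, a step that the two limits leave unreadable from compound 1 to compound 3, is equally unreadable; neither gives a size or a direction. Compound 4 is therefore expected to stay at the limit as well, with a step that the limit leaves unreadable from compound 3 to compound 4. The estimate for compound 4 in this assay is 20000 nM, between 6000 nM and 80000 nM.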

Compound 4, half-maximal inhibitory concentration: > 10000 nM
Compound 4: no number, only a limit (the forecaster's own chance of this, stated with the estimate: 85%); the middle value is on the limit's open side.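

Among these compounds, compound 4 gives > 10000 nM which is a limit of the assay, so no step to compound 4 from compound 3 or compound 2 can be read. The compounds shown leave open whether methoxy or phenoxy changes cytotoxicity at all.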